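Cyano for methyl on the sulfonyl aryl ring

A few compounds are considered here, and "the series" means these few. Any claim that something is new, unique, unknown or untested is made for them only; others in the source may bear on it.

Compound 2 `Cc1ccc(S(=O)(=O)c2cnc3ccc(C)cc3c2N2CCC(C)CC2)cc1` stands as the lower of the two numbers measured in an assay on isolated protein for displacement of a labelled ligand from metabotropic glutamate receptor 5 (Homo sapiens), with a stated time of 60 min, tested at 1 uM; a lower number here means less inhibition, a higher number more inhibition at the concentration tested (going by the name of the read-out). In this assay compound 2 gives 82%. Its nearest neighbour is compound 1 `Cc1ccc2ncc(S(=O)(=O)c3cccc(F)c3)c(N3CCC(C)CC3)c2c1`, which in this assay gives 94%; the step of a number 12 percentage points lower from compound 1 to compound 2 (beyond the scatter) came with 4-methylphenyl in place of 3-fluorophenyl on the sulfonyl sulfur.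

Compound 3 `Cc1ccc2ncc(S(=O)(=O)c3ccc(C#N)cc3)c(N3CCC(C)CC3)c2c1` is the unmeasured compound. It differs from compound 2 by cyano in place of methyl on an aromatic carbon, a change that keeps the same ring on the sulfonyl sulfur and alters only the group it carries.

Among the measured compounds shown here, only one measured step bears on this change, and that step, which was modest, swapped the whole substituted phenyl rather than exchanging methyl for cyano. For the measured compounds named here, no measured step reports what cyano does on this ring, so the step from compound 2 to compound 3 is expected to stay close to the scatter, with no firm direction, and the expectation is a number 3 percentage points higher from compound 2 to compound 3 (within the scatter). Compound 3 is therefore estimated to give 85% in this assay, within a range from 68% to 97%.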

Compound 3, a percentage reported as inhibition, at one concentration (the size of the read-out at that concentration, not a potency): 55%
Beside the measured number, compound 3's estimate is 30 percentage points above it; measured number below the stated range.
By their numbers in this assay, from the lowest: compound 3; then compound 2; then compound 1.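

In this assay, the group carried on the sulfonyl aryl ring, para to a large group, matters more than the earlier pair could show: keeping the ring and exchanging methyl for cyano gave a number 27 percentage points lower from compound 2 to compound 3 (beyond the scatter) and brought the inhibition at the tested concentration well down. Set against the 3-fluorophenyl of compound 1, the 4-cyanophenyl group gave a number 39 percentage points lower from compound 1 to compound 3 (beyond the scatter), which makes compound 3 the lowest of the three, with its steps to both others beyond the scatter. The earlier step, a number 12 percentage points lower from compound 1 to compound 2 (beyond the scatter), had shown only that this aryl group can be changed at a modest cost, whereas the new result shows that a single exchange on it can take away much of the reading, and no measurement at hand explains why.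

What the compounds shown leave open is whether this fall is particular to cyano, or whether an amine, a carboxylic acid or a methoxy group at the same place would read the same way. They also leave open how an unsubstituted phenyl on the sulfonyl sulfur would stand against these three, and so whether methyl and fluorine add to the reading or cyano alone takes away from it.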